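The source may report more compounds than this note shows. Statements on the series, on what has been measured and on what is new or still open speak of the compounds shown alone.

Compound 1 `O=C(O)CCc1ccc2[nH]c(-c3ccc(Cl)cc3Cl)cc2c1` is the reference point of this small series. Going by the values given here, in a functional assay on CHO cells for agonist activity at Free fatty acid receptor 1 (Homo sapiens), read by a luciferase reporter, with a stated time of 24 h (a higher number here means that more compound is needed for the effect, a lower number that less compound is needed), compound 1 gives 20.6 nM, which is the only numerical value reported so far. Compound 2 `O=C(O)CCc1ccc2[nH]c(-c3ccncc3Cl)cc2c1` is the second compound tested. For compound 2 in this assay only a limit of the assay is reported, not a number: > 25 nM. Compound 1 therefore stands against a single limit, (the limit of > 25 nM in this assay, at which 1 of the 2 values shown sits), and its position rests on one number alone.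

Compound 3 `O=C(O)CCc1ccc2[nH]c(-c3ccc(Cl)cc3C(F)(F)F)cc2c1` differs from compound 1 in one place: trifluoromethyl in place of chloro on an aromatic carbon. No measured step for this kind of exchange exists among the compounds shown, so the expectation rests on the structural change by itself. The step expected from compound 1 to compound 3 in this assay is a 1.1-fold lower number from compound 1 to compound 3 (0.06 log units; within the scatter), which is not beyond the usual scatter in either direction. Compound 3 is thus estimated to give 18 nM in this assay, with a range from 6 nM to 55 nM.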

Compound 3, half-maximal effective concentration: > 25 nM
Compound 3: a limit, no number (the forecaster's own chance of this, stated with the estimate: 15%); middle value at least 1.3-fold (0.14 log units) away from the limit.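

In this assay compound 3 gives > 25 nM, which is a limit of the assay and not a number. Trifluoromethyl in place of chloro at this position, ortho to a large group and meta to a chloro group, gives an at least 1.2-fold higher number from compound 1 to compound 3 (0.08 log units; that floor lies within the scatter); this fixes only a floor for the change, and its true size remains unknown. This is the first step readable at this position, and the series now has a second compound at the limit: the limit of > 25 nM in this assay, at which 2 of the 3 values shown sit.

Going by these compounds, whether the true number for compound 3 lies close to that of compound 1 or far from it remains open. Also open, on these data alone, is how a smaller or differently built group at this position, such as methyl, methoxy, nitrile or an amine, would read in this assay.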